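The source may report more compounds than this note shows. Statements on the series, on what has been measured and on what is new or still open speak of the compounds shown alone.

Compound 1 `Cc1ccccc1NNC(=O)C1CCCCC1`: 174 nM in an in vitro functional assay on 1321-N1 cells for antagonist activity at P2X purinoceptor 7 (Homo sapiens), read by FLIPR and calcium flux; a higher number here means a weaker inhibitor, a lower number a stronger inhibitor
Compound 2 `O=C(NNc1cccc2ncccc12)C1(c2ccccc2F)CCCCC1`: 191 nM

In this assay compound 2 and compound 1 give numbers that lie within the scatter of each other, so the two cannot be told apart. Compound 3 `O=C(NNc1cccc2ncccc12)C1(c2ccc(F)cc2)CCCCC1` differs from compound 2 only in one place: 4-fluorophenyl in place of 2-fluorophenyl on a saturated ring carbon. For the measured compounds named here, with no comparable step among the measured compounds, no shift beyond the scatter is expected in either direction. Compound 3 is therefore estimated at 200 nM, with a range from 70 nM to 600 nM; the expected step from compound 2 to compound 3 is a 1.0-fold higher number from compound 2 to compound 3 (0.02 log units; within the scatter).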

Compound 3, half-maximal inhibitory concentration: 70.8 nM
Beside the measured number, compound 3's estimate is 2.8-fold (0.45 log units) above it; low and high end bracket the measured number.
By their numbers in this assay, from the lowest: compound 3; then compounds 1 and 2 (each within the scatter of the next).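

In this assay, 4-fluorophenyl in place of 2-fluorophenyl on a saturated ring carbon gives a 2.7-fold lower number from compound 2 to compound 3 (0.43 log units; beyond the scatter) even though both groups contain the same atoms. This position therefore responds to where the fluorine sits on the phenyl group, not only to which atoms are present. Nothing available explains why the numbers differ.

The compounds shown leave open how an unsubstituted phenyl, 4-chlorophenyl or 4-methoxyphenyl would compare with 4-fluorophenyl on this carbon.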